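A few compounds are considered here, and "the series" means these few. Any claim that something is new, unique, unknown or untested is made for them only; others in the source may bear on it.

In an assay on isolated protein (blood) for antagonist activity at C-C chemokine receptor type 4 (Homo sapiens), read by flow cytometry, with a stated time of 30 min; a lower number here means tighter binding, a higher number weaker binding:
compound 1 `CC(=O)NCc1cccc(Cn2nc(NS(=O)(=O)c3ccc(Cl)s3)c3c(F)cccc32)c1` gives 5010 nM;
compound 2 `COc1cccc2c1c(NS(=O)(=O)c1ccc(Cl)s1)nn2Cc1cccc(CNC(=O)C2COC2)c1` gives 1000 nM.

Compound 2 holds the lower of the two numbers in this assay; compound 1 is its nearest neighbour, and that gap lies beyond the scatter. Compound 3 `COc1cccc2c1c(NS(=O)(=O)c1ccc(Cl)s1)nn2Cc1cccc(CNC(=O)[C@@H]2CCCCN2)c1` differs from compound 2 in one place: piperidin-2-yl in place of oxetan-3-yl on a carbonyl carbon. Among the measured compounds shown here, no measured pair carries this change, so its size rests on no precedent. A small step in this assay is expected, not clearly beyond the scatter, with no firm direction. Compound 3 is estimated at 700 nM, range 200 nM to 3000 nM. The expected step is a 1.4-fold lower number from compound 2 to compound 3 (0.15 log units; within the scatter).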

Compound 3, dissociation constant: 126 nM
Beside the measured number, compound 3's estimate is 5.6-fold (0.74 log units) above it; measured number below the stated range.
By their numbers in this assay, from the lowest: compound 3; then compound 2; then compound 1.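

In this assay, the group on the carbonyl carbon is a place where the number moves: piperidin-2-yl in place of oxetan-3-yl gives a 7.9-fold lower number from compound 2 to compound 3 (0.90 log units; beyond the scatter). The change replaces a four-membered ring with a six-membered ring and brings in a hydrogen-bond donor and a defined stereocentre at once, and the pair does not separate these differences. Nothing measured here accounts for the step. Going by these compounds, it remains open whether cyclohexyl, a six-membered ring without the nitrogen, keeps the step. On these data alone, the opposite stereoisomer of piperidin-2-yl is equally open.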